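This account rests on a few compounds, and the source may have more. Where it says the series, first, only, none or still open, it means among the compounds named here.

Among the measured compounds shown here, in a functional assay on HCT-116 cells (Homo sapiens) for antiproliferative activity, read by MTT assay, with a stated time of 72 h (a lower number here means a stronger inhibitor, a higher number a weaker inhibitor), compound 1 (`CC(C)c1cccc(NC(=O)CCc2cccc3c2B(O)OC3)c1`) gives 1600 nM and compound 2 (`CSc1cccc(-c2cccc(NC(=O)CCc3cccc4c3B(O)OC4)c2)c1`) gives 110 nM as the lowest of the two numbers so far. For the measured compounds named here, the only measured step is a 15-fold lower number from compound 1 to compound 2 (1.16 log units; beyond the scatter) and it lies beyond the scatter, with 3-(methylsulfanyl)phenyl in place of isopropyl on an aromatic carbon. Compound 3 (`CC(=O)c1cccc(-c2cccc(NC(=O)CCc3cccc4c3B(O)OC4)c2)c1`) keeps the shared core and amide chain of compound 2, and the change is acetyl in place of methylsulfanyl on an aromatic carbon in which acetyl takes the place of methylsulfanyl on an aromatic carbon, so that 3-(methylsulfanyl)phenyl becomes 3-acetylphenyl. Going by the values given here, that single large step bears only indirectly, since it brought in the whole substituted ring, and no measurement yet compares groups on that ring. A step far smaller than that one is therefore expected in this assay with no firm direction, most likely within the scatter and with a slightly higher number if anything. The expected change is a 1.5-fold higher number from compound 2 to compound 3 (0.16 log units; within the scatter) on this estimate. For compound 3 the estimated value is 160 nM with an expected range from 55 nM to 450 nM at this stage.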

Compound 3, half-maximal inhibitory concentration: 86 nM
Compound 3: middle estimate off by 1.9-fold (0.27 log units), on the high side; measured number inside the range.
By their numbers in this assay, from the lowest: compounds 3 and 2 (each within the scatter of the next); then compound 1.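

In this assay, among the compounds shown here, this is the first comparison of two groups on the added ring, and a 1.3-fold lower number from compound 2 to compound 3 (0.11 log units; within the scatter) leaves methylsulfanyl and acetyl unseparated at this place, on an aromatic carbon meta to a large group. The two groups are not told apart even though the swap takes out sulfur and brings in oxygen, one more heavy atom and a double bond outside aromatic rings. The large drop from the isopropyl compound also appears with the second group, as a 19-fold lower number from compound 1 to compound 3 (1.27 log units; beyond the scatter) shows, so within these compounds it is not tied to methylsulfanyl alone, and nothing measured here accounts for either step.

Open, going by these compounds, is how far this tolerance reaches, since an amine, a carboxylic acid or a longer chain at the same place could read quite differently from acetyl and methylsulfanyl. Also open, on these data alone, is how much of the large step belongs to the added ring itself, which a plain phenyl with no group on it would separate from the contribution of the acetyl or methylsulfanyl group.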